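Amide-side variation on the adenosine A2b antagonist series

The compounds below may be only part of what the source reports. "The series", "measured", "known", "first", "only" and "open" are said of these compounds alone.

Measured so far:
compound 1 `O=C(COc1ccc2[nH]c(=O)c(-c3nccs3)c(CCc3ccccc3)c2c1)NC1(c2ccccc2)CC1`: 4.5 nM
compound 2 `CC(C)(NC(=O)COc1ccc2[nH]c(=O)c(-c3ccccn3)c(CCc3ccccc3)c2c1)c1ccccc1`: 504 nM
compound 3 `COCCCNC(=O)COc1ccc2c(c1)c(CCc1ccccc1)c(-c1ccc(F)cc1F)c(=O)n2C`: 633 nM

In a functional assay on CHO cells for antagonist activity at adenosine receptor A2b (Homo sapiens), read by cAMP accumulation, with stated times of 15 min and 1 h (on this read-out lower numbers stand for stronger inhibition and higher numbers for weaker inhibition), compound 1 gives the lowest of the three numbers; compound 2 and compound 3 both lie well beyond the scatter above it. For the measured compounds named here, compound 2 and compound 3 differ from compound 1 in more than one place, so no single step is drawn from them.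

Compound 4 `CC[C@H](NC(=O)COc1ccc2[nH]c(=O)c(-c3nccs3)c(CCc3ccccc3)c2c1)c1ccccc1` is not yet measured. The change from compound 1 is 1-phenylpropyl in place of 1-phenylcyclopropyl on an amide-type nitrogen. Going by the values given here, no comparable step exists among the measured compounds. Opening the three-membered ring in this way is expected to cost somewhat, with the step from compound 1 to compound 4 estimated at a 3.3-fold higher number from compound 1 to compound 4 (0.52 log units; beyond the scatter). Compound 4 is therefore expected to give about 15 nM, between 4 nM and 60 nM.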

Compound 4, inhibition constant: 7.4 nM
Compound 4: middle estimate off by 2.0-fold (0.31 log units), on the high side, within the range that was stated.
By their numbers in this assay, from the lowest: compounds 1 and 4 (each within the scatter of the next); then compounds 2 and 3 (each within the scatter of the next).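

In this assay, for the compounds shown here, 1-phenylpropyl in place of 1-phenylcyclopropyl on the amide-type nitrogen, with the rest of compound 1 unchanged, gives the first readable step (a 1.6-fold higher number from compound 1 to compound 4 (0.22 log units; within the scatter)). At this position, the closed three-membered ring is therefore not required for a low number, at least with this core. Nothing available explains why the two groups read alike.

Only one defined stereocentre configuration of 1-phenylpropyl is shown, so the opposite configuration remains open. Also open, from the compounds shown here alone, is how far this position accepts a longer chain such as 1-phenylbutyl, or an amine on the propyl chain.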